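This account rests on a few compounds, and the source may have more. Where it says the series, first, only, none or still open, it means among the compounds named here.

Compound 1, `CCc1nc2ccccc2n1CCCCOc1cccc(C)c1`: 19 uM
Compound 2, `CCc1nc2ccccc2n1CCCCOc1ccc(C)c(C)c1`: 14 uM
Compound 3, `CCc1nc2ccccc2n1CCCCOc1ccc(Cl)cc1F`: 5.7 uM

In an ADME assay on Vero cells (Chlorocebus sabaeus) for cytotoxicity, read by luminescence, with a stated time of 2 days (a lower number here means that less compound is tolerated, a higher number that more compound is tolerated), compound 2 stands second highest of the three measured numbers. Its nearest neighbour is compound 1, with a 1.4-fold lower number from compound 1 to compound 2 (0.13 log units; within the scatter), a gap within the scatter; its furthest is compound 3, with a 2.5-fold lower number from compound 2 to compound 3 (0.39 log units; beyond the scatter), a modest gap beyond the scatter.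

Compound 4, `CCc1nc2ccccc2n1CCCCOc1ccc(C)c(Cl)c1`, differs from compound 2 by chloro in place of methyl on an aromatic carbon. Going by the values given here, two measured steps bear on this. The step of a 1.4-fold lower number from compound 1 to compound 2 (0.13 log units; within the scatter) shows that adding a methyl barely moved the number. The step of a 2.5-fold lower number from compound 2 to compound 3 (0.39 log units; beyond the scatter) shows that swapping both methyls for a chloro and a fluoro lowered it modestly. A single chloro in place of one methyl is therefore expected to give a small downward step, likely within or just beyond the scatter.

Compound 4 is estimated at 10 uM, with a range from 5 uM to 20 uM. That estimate means an expected step of a 1.4-fold lower number from compound 2 to compound 4 (0.15 log units; within the scatter).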

Compound 4, half-maximal toxic concentration: 14 uM
Compound 4: the middle estimate sits 1.4-fold (0.15 log units) below what was measured, and the stated range covers the measured number.
By their numbers in this assay, from the lowest: compound 3; then compounds 2, 4 and 1 (each within the scatter of the next).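

In this assay, chloro in place of methyl, ortho to a methyl group, leaves the number unchanged (no change at the digits printed from compound 2 to compound 4 (within the scatter)), and the 3-chloro-4-methylphenyl group also stays within the scatter of the 3-methylphenyl group (a 1.4-fold lower number from compound 1 to compound 4 (0.13 log units; within the scatter)). A chloro on this ring therefore does not by itself bring the lower number, since compound 3 also carries one yet stands apart (a 2.5-fold higher number from compound 3 to compound 4 (0.39 log units; beyond the scatter)). No measurement at hand gives a cause for this. Still open, on these data alone, is whether the fluoro or the chloro's place sets compound 3 apart, and what an amine or a carboxylic acid on this ring would do.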